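Working notes: compound 2 to compound 3

The source may report more compounds than this note shows. Statements on the series, on what has been measured and on what is new or still open speak of the compounds shown alone.

Measured so far:
compound 1 `Nc1ccccc1NC(=O)c1ccc(CSC(=S)N2CCN(c3ccc(Cl)cc3)CC2)cc1` gives 32.2% in a functional assay on A-375 cells (Homo sapiens) for antiproliferative activity, read by CCK-8 assay, with a stated time of 72 h, tested at 2 uM; a higher number here means a stronger effect of the compound at the concentration tested, a lower number a weaker effect
compound 2 `CN(C(=S)SCc1ccc(C(=O)Nc2ccccc2N)cc1)c1cccnc1` gives 26.5% in this assay

On the bare numbers compound 2 stands as the lower of the two, but its gap to compound 1 is within the scatter, so the two read alike.

Compound 3 `CC1CCCCN1C(=S)SCc1ccc(C(=O)Nc2ccccc2N)cc1` is not yet measured. It differs from compound 2 by 2-methylpiperidin-1-yl in place of methyl(pyridin-3-yl)amino on a thiocarbonyl carbon.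

Within the data shown here, no step between measured compounds is available for this change. The expected step of a number 3.5 percentage points higher from compound 2 to compound 3 (within the scatter) is small, likely not beyond the scatter in either direction. For compound 3 the estimate in this assay is 30%, with a range from 15% to 45%.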

Compound 3, a percentage reported as inhibition, at one concentration (the size of the read-out at that concentration, not a potency): 42.5%
Beside the measured number, compound 3's estimate is 12.5 percentage points below it; low and high end bracket the measured number.
By their numbers in this assay, from the lowest: compounds 2 and 1 (each within the scatter of the next); then compound 3.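

In this assay, among these compounds, the position on the thiocarbonyl carbon now gives the first single change that is readable beyond the scatter: 2-methylpiperidin-1-yl in place of methyl(pyridin-3-yl)amino gives a number 16 percentage points higher from compound 2 to compound 3 (beyond the scatter). An aromatic ring with a hetero atom is therefore not required at this position for this read-out, since a non-aromatic ring serves there too. Nothing at hand accounts for the step.

As far as these compounds go, it remains open whether the methyl group matters, or whether piperidin-1-yl or morpholin-4-yl would keep the gain. A single concentration also leaves potency unresolved.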